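The source may hold more compounds than are shown below. What is called first, only, known or untested is meant among the compounds shown, and "the series" means these compounds.

Measured so far:
- Compound 1 `COc1ccc(/C=C2\CN(C)C/C(=C\c3ccccc3F)C2=O)cc1`: 18400 nM
- Compound 2 `COc1cc(/C=C2\CN(C)C/C(=C\c3cc(OC)c(OC)c(OC)c3)C2=O)cc(OC)c1`: 3470 nM

Both values come from a functional assay on K562 cells (Homo sapiens) for cytotoxicity, read by MTT assay, with a stated time of 24 h; a higher number here means a weaker inhibitor, a lower number a stronger inhibitor. Compound 2 holds the lower of the two numbers at 3470 nM, while compound 1 stands at 18400 nM, a gap beyond the usual scatter of repeat measurements. These two compounds differ in more than one place, so their gap cannot be tied to any single structural change.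

The next compound, compound 3 `COc1cc(/C=C2\CN(C)C/C(=C\c3ccc(Cl)c(Cl)c3)C2=O)cc(OC)c1OC`, has not yet been measured. It differs from compound 2 in one place: 3,4-dichlorophenyl in place of 3,5-dimethoxyphenyl on a double-bonded chain carbon bound to a double-bonded ring carbon. It carries 3,4-dichlorophenyl in place of 3,5-dimethoxyphenyl on a double-bonded chain carbon bound to a double-bonded ring carbon.

Within the data shown here, no measured pair shows this change on its own, so the expectation rests on little evidence. The estimated step is a 1.4-fold lower number from compound 2 to compound 3 (0.14 log units; within the scatter), a small move towards a lower number that is not expected to go beyond the scatter. Compound 3 is expected in this assay at 2500 nM, with an estimated range from 700 nM to 9000 nM.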

Compound 3, half-maximal inhibitory concentration: 16200 nM
Compound 3: middle estimate off by 6.5-fold (0.81 log units), on the low side; measured number above the stated range.
By their numbers in this assay, from the lowest: compound 2; then compounds 3 and 1 (each within the scatter of the next).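

In this assay, the position on a double-bonded chain carbon bound to a double-bonded ring carbon now has its first readable step: placing 3,4-dichlorophenyl there instead of 3,5-dimethoxyphenyl gives a 4.7-fold higher number from compound 2 to compound 3 (0.67 log units; beyond the scatter). The two earlier compounds differ in more than one place and could not show this, but the pair now shows that the number in this assay responds to the group at this position, and that this change weakens the compound, on the evidence of this single pair. Nothing measured here explains the size or direction of the step.

The compounds shown leave open whether the step follows from the chlorine atoms themselves or from where they stand on the ring, a question that 3,5-dichlorophenyl at this position would separate from the change of substituent. Also open, going by these compounds, is where a phenyl ring carrying a nitrile or a carboxylic acid would fall in this assay, and whether the step from compound 2 to compound 3 would keep its size with a different group at the other end of the core.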